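The source may hold more compounds than are shown below. What is called first, only, known or untested is meant among the compounds shown, and "the series" means these compounds.

Measured compounds:
Compound 1 `Cc1cc(-c2cccc(F)c2)c2ncc(CSCCc3ccccc3)n2c1` gives 20 ug/mL
Compound 2 `Cc1cc(I)cn2c(CSCCc3ccccc3)cnc12` gives >= 0.8 ug/mL, a limit
Compound 3 `COc1ccc(-c2cc(C)cn3c(CSCCc4ccccc4)cnc23)cc1` gives 20 ug/mL

Three compounds share one core and differ only in the group on one aromatic carbon. Among the compounds with values here, in an ADME assay on HEL cells (Homo sapiens) for cytotoxicity, with a stated time of 3 days (on this read-out higher numbers stand for lower toxicity in this test and lower numbers for higher toxicity in this test), compound 1 gives 20 ug/mL and compound 3 gives 20 ug/mL; the single measured step, no change at the digits printed from compound 1 to compound 3 (within the scatter), shows that exchanging one aryl group for another leaves the read-out where it was. For compound 2 only a limit is known: in this assay compound 2 reaches >= 0.8 ug/mL, which is the limit of >= 0.8 ug/mL in this assay, at which 1 of the 3 values shown sits, and not a number.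

Compound 4 `Cc1cc(-c2ccccc2O)cn2c(CSCCc3ccccc3)cnc12` is the unmeasured compound, and the change from compound 2 to compound 4 is 2-hydroxyphenyl in place of iodo on an aromatic carbon. Within the data shown here, no measured step covers a move away from iodo, so the bearing evidence is indirect: compounds 1 and 3 each carry an aryl group at this place and both sit at the same value. Compound 4 is therefore expected to land near them, at an estimated 20 ug/mL with a range from 4 ug/mL to 100 ug/mL, which means an expected step that the limit leaves unreadable from compound 2 to compound 4.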

Compound 4, minimum cytotoxic concentration: 100 ug/mL
Estimate against measurement, compound 4: 5.0-fold (0.70 log units) below; the measured number falls inside the stated range.
By their numbers in this assay, from the lowest: compounds 1 and 3 (each within the scatter of the next); then compound 4.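

No size can be given for the step between compound 2 and compound 4, because the value for compound 2 is a limit and not a number: the limit of >= 0.8 ug/mL in this assay, at which 1 of the 4 values shown sits.

In this assay the compounds shown leave open how far 2-hydroxyphenyl in place of iodo actually moves the read-out.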